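Methoxy addition on the aryl ring of aminochalcones

A few compounds are considered here, and "the series" means these few. Any claim that something is new, unique, unknown or untested is made for them only; others in the source may bear on it.

In a functional assay on MOLT-4 cells (Homo sapiens) for antiproliferative activity, with a stated time of 48 h (on this read-out lower numbers stand for stronger inhibition and higher numbers for weaker inhibition), compound 1 `C=C(Br)C(=O)Nc1ccc(C(=O)/C=C/c2ccc(OC)c(OC)c2)cc1` gives 1800 nM. Compound 2 `C=C(Br)C(=O)Nc1ccc(C(=O)/C=C/c2cc(OC)c(OC)c(OC)c2)cc1` carries one more methoxy group: methoxy in place of hydrogen on an aromatic carbon In this assay compound 2 gives 280 nM. This change made a 6.4-fold lower number from compound 1 to compound 2 (0.81 log units; beyond the scatter). Compound 3 `Nc1ccc(C(=O)/C=C/c2ccccc2)cc1` gives 7900 nM in this assay, the highest number of the three measured compounds; the difference between its core and the core of compound 1 is not broken down here. Compound 4 `COc1cccc(/C=C/C(=O)c2ccc(N)cc2)c1` differs from compound 3 by the same kind of change: methoxy in place of hydrogen on an aromatic carbon The place differs: in compound 2 the new methoxy stands ortho to a methoxy group and meta to a methoxy group as well as meta to a large group, whereas in compound 4 it stands only meta to a large group. For the measured compounds named here, the step is therefore expected to be smaller than the one seen from compound 1 to compound 2. For compound 4 a step of a 2.3-fold lower number from compound 3 to compound 4 (0.35 log units; beyond the scatter) is expected. Compound 4 is thus estimated at 3500 nM, with a range from 1500 nM to 9000 nM.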

Compound 4, half-maximal inhibitory concentration: 21000 nM
For compound 4 the middle estimate is 6.0-fold (0.78 log units) below the measured one; the whole stated range lies below it.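

The methoxy change gives a 2.7-fold higher number from compound 3 to compound 4 (0.42 log units; beyond the scatter) in this assay, so it does not carry over from one core to another as a fixed gain: the same change on two cores in this assay, a 6.4-fold lower number (0.81 log units; beyond the scatter) from compound 1 to compound 2 and a 2.7-fold higher number (0.42 log units; beyond the scatter) from compound 3 to compound 4, 17-fold (1.23 log units) apart, beyond the scatter of two such steps

The two pairs differ in core and also in the place of the new methoxy, and they cannot separate these two differences. They show that the sign of the step is not constant in this series, but not which difference sets it.

On these data alone, it remains open what a methoxy placed only meta to a large group would do on the core of compound 1. Also open, as far as these compounds go, is whether a hydroxy group or a fluorine atom in place of hydrogen on compound 3 would follow the methoxy step.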